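Notes on compound 4: fluoro exchanged for trifluoromethyl

A few compounds are considered here, and "the series" means these few. Any claim that something is new, unique, unknown or untested is made for them only; others in the source may bear on it.

Measured so far:
compound 1 `CCCCOc1ccc(C(CC(=O)O)c2ccccc2)cc1`; in a functional assay on HEK293 cells for agonist activity at Free fatty acid receptor 1 (Homo sapiens), read by calcium flux (on this read-out higher numbers stand for an effect only at larger amounts of compound and lower numbers for an effect already at smaller amounts), compound 1 gives 1.2 uM
compound 2 `CCCCCOc1ccc(C(CC(=O)O)c2ccccc2)cc1`; compound 2 gives 2.97 uM
compound 3 `CCCCOc1ccc(C(CC(=O)O)c2cccc(F)c2)cc1`; compound 3 gives 1.44 uM

Compound 3 holds the second highest of the three numbers. Its nearest neighbour is compound 1, separated by a gap within the scatter; the furthest is compound 2, separated by a gap beyond the scatter.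

Compound 4 `CCCCOc1ccc(C(CC(=O)O)c2cccc(C(F)(F)F)c2)cc1` carries trifluoromethyl in place of fluoro on an aromatic carbon. Within the data shown here, no measured step exchanges one group for another on this ring, so the bearing steps are indirect. The step of a 1.2-fold higher number from compound 1 to compound 3 (0.08 log units; within the scatter) shows that placing fluoro on that ring leaves the number within the scatter. Among the measured compounds shown here, the only step beyond the scatter, a 2.5-fold higher number from compound 1 to compound 2 (0.39 log units; beyond the scatter), concerns the chain and is modest. From these, a small step towards a higher number is expected for compound 4 in this assay, at the edge of the scatter: a 1.4-fold higher number from compound 3 to compound 4 (0.14 log units; within the scatter). Compound 4 is estimated to give 2 uM, with a range from 0.9 uM to 4.5 uM.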

Compound 4, concentration for half-maximal effect: 2.84 uM
Compound 4: middle estimate off by 1.4-fold (0.15 log units), on the low side, and the stated range covers the measured number.
By their numbers in this assay, from the lowest: compounds 1, 3, 4 and 2 (each within the scatter of the next, the first and the last beyond it).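

In this assay, trifluoromethyl in place of fluoro on this aromatic carbon gives a 2.0-fold higher number from compound 3 to compound 4 (0.29 log units; within the scatter), so four heavy atoms instead of one at this place do not separate compound 4 from compound 3 beyond the scatter. Against hydrogen, the picture differs: trifluoromethyl gives a 2.4-fold higher number from compound 1 to compound 4 (0.37 log units; beyond the scatter), the first change on this ring to pass the scatter, though only modestly, while fluoro gives a 1.2-fold higher number from compound 1 to compound 3 (0.08 log units; within the scatter). No supporting data bear on what lies behind these steps.

As far as these compounds go, it remains open whether a nitrile, a methoxy group or a tert-butyl group on the same aromatic carbon would stay within the scatter of compound 1 or move beyond it, as trifluoromethyl does. Also open, from the compounds shown here alone, is whether trifluoromethyl would give a similar step on the longer chain of compound 2.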